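The source may report more compounds than this note shows. Statements on the series, on what has been measured and on what is new or still open speak of the compounds shown alone.

Compound 1 `Cc1nc(C(NC(=O)C(=O)Nc2ccc(Cl)cc2)C2CCCCN2)sc1CO` gives > 22000 nM in an ADME assay on TZM-b1 cells (Homo sapiens) for cytotoxicity, read by XTT assay, with a stated time of 3 days (a higher number here means that more compound is tolerated, a lower number that less compound is tolerated), which is a limit of the assay and not a number. Compound 2 `Cc1ccc(NC(=O)C(=O)NC(c2nc(C)c(CO)s2)C2CCCCN2)c(F)c1` gives > 88000 nM in this assay, again only a limit. Compound 3 `Cc1nc(C(NC(=O)C(=O)Nc2ccc(F)cc2)C2CCCCN2)sc1CO` gives > 90000 nM in this assay, also a limit.

Compound 3 thus stands at a limit, as do the two other values shown (the limit of > 90000 nM in this assay, at which 1 of the 3 values shown sits). Compound 4 `Cc1nc(C(NC(=O)C(=O)Nc2ccc(C(F)(F)F)cc2)C2CCCCN2)sc1CO` differs from compound 3 by trifluoromethyl in place of fluoro on an aromatic carbon. All measured steps sit between limits: a step that the two limits leave unreadable from compound 1 to compound 3, a step that the two limits leave unreadable from compound 1 to compound 2 and a step that the two limits leave unreadable from compound 2 to compound 3 cannot be read in size, so no direction for the change to compound 4 can be drawn from them, and no step beyond the scatter is expected in this assay. The step estimated here is a number no higher from compound 3 to compound 4 (the limit leaves the size open). Compound 4 is expected to give 90000 nM, within 20000 nM to 200000 nM, most likely again reported as a limit.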

Compound 4, half-maximal cytotoxic concentration: > 75500 nM
Compound 4: no number, only a limit; the forecaster's own chance of this, stated with the estimate: 80%; the middle value does not contradict the limit.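

In this assay, for the compounds shown here, compound 4 gives only a limit, as do compound 1, compound 2 and compound 3, so no step among them can be read. The compounds shown leave open what concentration of any of them is actually tolerated, and whether changing the substituted phenyl group alters it.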